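A Thiophene in Place of a Tolyl Group

The source may report more compounds than this note shows. Statements on the series, on what has been measured and on what is new or still open speak of the compounds shown alone.

Of the compounds shown here, three on a shared core have been tested in an assay on isolated protein for inhibition of malate dehydrogenase, mitochondrial (Sus scrofa), with stated times of 45 min and 30 min; on this read-out lower numbers stand for stronger inhibition and higher numbers for weaker inhibition. Compound 1 `O=S(=O)(Nc1ccc(-c2nc3ccccc3o2)cc1)c1ccc(Cl)c(C(F)(F)F)c1` reaches only the limit of the assay, giving > 63000 nM. Compound 2 `Cc1ccc(S(=O)(=O)Nc2ccc3oc(-c4ccccc4)nc3c2)cc1` likewise gives just the limit, > 63000 nM. Compound 3 `O=S(=O)(Nc1ccc(-c2nc3ccccc3o2)cc1)c1ccccc1F` also stops at the limit, with > 63000 nM. Compound 2 thus stands level with the others, as shown by the limit of > 63000 nM in this assay, at which 3 of the 3 values shown sit. Compound 4 `O=S(=O)(Nc1ccc2oc(-c3ccccc3)nc2c1)c1cccs1` differs from compound 2 in one place: thiophen-2-yl in place of 4-methylphenyl on a sulfonyl sulfur. For the measured compounds named here, no measured pair differs in only one place, so no step size is known from the data; with every value at the limit, no shift beyond the scatter is expected in either direction. Compound 4 is therefore expected to give 100000 nM, within 30000 nM to 300000 nM. The step that the limit leaves unreadable from compound 2 to compound 4 is estimated to stay within the scatter.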

Compound 4, half-maximal inhibitory concentration: > 63000 nM
Compound 4: no number, only a limit (the forecaster's own chance of this, stated with the estimate: 85%); the middle value lies beyond the limit too.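

No step can be read from compound 2 to compound 4, because both stop at a limit of the assay rather than giving a number: the limit of > 63000 nM in this assay, at which 4 of the 4 values shown sit.

The compounds shown leave open how thiophen-2-yl and 4-methylphenyl truly compare, and which change to the shared core, if any, would give a measurable value.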